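Adding a second hydroxy to a benzofuran-quinolinol core

A few compounds are considered here, and "the series" means these few. Any claim that something is new, unique, unknown or untested is made for them only; others in the source may bear on it.

Measured so far:
compound 1, `Oc1ccc(-c2cc3ccccc3o2)c2cccnc12`, 4.3 10^-6 cm/s
compound 2, `Oc1ccc(-c2cc3cccc(O)c3o2)c2cccnc12`, 14.5 10^-6 cm/s
compound 3, `Oc1ccc2cc(-c3cc(I)c(O)c4ncccc34)oc2c1`, 16.6 10^-6 cm/s

These three were tested in an ADME assay for permeability, using PAMPA, with a stated time of 10 h, tested at 100 ug/mL; on this read-out higher numbers stand for higher permeability and lower numbers for lower permeability. Compound 1 gives 4.3 10^-6 cm/s there. The change from compound 1 to compound 2, (hydroxy in place of hydrogen on an aromatic carbon), brought a 3.4-fold higher number from compound 1 to compound 2 (0.53 log units; beyond the scatter). Compound 3 has a different core; how its core differs from that of compound 1 is not broken down here. In this assay compound 3 gives 16.6 10^-6 cm/s, which is within the scatter of compound 2.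

Compound 4, `Oc1cc(O)c2cc(-c3cc(I)c(O)c4ncccc34)oc2c1`, is not yet measured. It differs from compound 3 by hydroxy in place of hydrogen on an aromatic carbon. This is the same kind of change as from compound 1 to compound 2, but not the same: in compound 4 the new group also sits meta to a hydroxy group, a surrounding the earlier pair does not share. On one prior step of this kind, seen once, the expectation for compound 4 in this assay is a 1.2-fold higher number from compound 3 to compound 4 (0.08 log units; within the scatter), smaller than the earlier step because that step, a 3.4-fold higher number from compound 1 to compound 2 (0.53 log units; beyond the scatter), occurred on a core without the extra hydroxy and iodine. Compound 4 is therefore estimated at 20 10^-6 cm/s, with a range from 8 10^-6 cm/s to 45 10^-6 cm/s.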

Compound 4, apparent permeability: 0.8 10^-6 cm/s
Compound 4: the middle estimate sits 25-fold (1.40 log units) above what was measured; the measured number lies below the stated range.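

In this assay, the same swap of hydrogen for hydroxy on an aromatic carbon gave a 21-fold lower number from compound 3 to compound 4 (1.32 log units; beyond the scatter), and this does not repeat the earlier step on the other core: the same change on two cores in this assay, a 3.4-fold higher number (0.53 log units; beyond the scatter) from compound 1 to compound 2 and a 21-fold lower number (1.32 log units; beyond the scatter) from compound 3 to compound 4, 70-fold (1.84 log units) apart, beyond the scatter of two such steps. The change therefore cannot be carried from one core to another in this series as a fixed amount, and across these two pairs even the direction of the number reverses. Within the data shown here, what the pairs do not show is which difference between the two cores decides the outcome, as each core offers only one example and the cores differ in more than one place.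

The compounds shown leave open whether the drop belongs to hydroxy itself or would also appear with another group in the same place on the core of compound 3, such as methoxy or an amine. They also leave open what the new hydroxy would do on a core that keeps the other hydroxy of compound 3 but lacks its iodine.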